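This account rests on a few compounds, and the source may have more. Where it says the series, first, only, none or still open, it means among the compounds named here.

Compound 2 `O=C(O)CCCCCC[C@@H]1[C@@H](CC[C@@H](O)CCc2ccc(F)cc2)[C@H](O)C[C@@H]1O` gives the lowest of the two numbers measured in an in vitro assay on CHO-KI cells for displacement of a labelled ligand from prostaglandin E2 receptor EP1 subtype (Homo sapiens) (a higher number here means a weaker inhibitor, a lower number a stronger inhibitor), at 3450 nM. Among the measured compounds shown here, compound 1 `O=C(O)CCCCCC[C@@H]1[C@@H](CC[C@@H](O)CCc2cccc(F)c2)[C@H](O)C[C@@H]1O` gives 10000 nM in this assay, and the only measured step is a 2.9-fold lower number from compound 1 to compound 2 (0.46 log units; beyond the scatter). Compound 3 `Cc1ccccc1CC[C@H](O)CC[C@@H]1[C@@H](CCCCCCC(=O)O)[C@@H](O)C[C@H]1O` carries 2-methylphenyl in place of 4-fluorophenyl on a saturated chain carbon, three bonds along the chain from an oxygen on a saturated carbon. That single step concerns only where fluorine sits on the ring, not an exchange of fluorine for methyl, so it bears on this change loosely and shows a modest move. Compound 3 is therefore expected to stay near compound 2, with no clear direction. The expected step is a 1.4-fold higher number from compound 2 to compound 3 (0.16 log units; within the scatter). For compound 3 the estimate in this assay is 5000 nM, range 1500 nM to 15000 nM.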

Compound 3, half-maximal inhibitory concentration: 10000 nM
Beside the measured number, compound 3's estimate is 2.0-fold (0.30 log units) below it; the range from low to high includes it.
By their numbers in this assay, from the lowest: compound 2; then compounds 1 and 3 (each within the scatter of the next).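

In this assay the change from 4-fluorophenyl to 2-methylphenyl at this position gives a 2.9-fold higher number from compound 2 to compound 3 (0.46 log units; beyond the scatter) and so extends the series beyond fluorine-bearing rings. The step of no change at the digits printed from compound 1 to compound 3 (within the scatter) leaves 2-methylphenyl and 3-fluorophenyl indistinguishable here, so compound 2 alone stands apart from the other two. No measured evidence on what lies behind these steps is available.

Open, as far as these compounds go, is whether the lower number of compound 2 follows the fluorine itself or its place on the ring. 4-Methylphenyl and 2-fluorophenyl at this position would separate the two, and unsubstituted phenyl would give a reference for all three rings.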